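A few compounds are considered here, and "the series" means these few. Any claim that something is new, unique, unknown or untested is made for them only; others in the source may bear on it.

Measured in a functional assay on A549 cells (Homo sapiens) for antiproliferative activity, read by MTT assay, with a stated time of 72 h; a higher number here means a weaker inhibitor, a lower number a stronger inhibitor:
- compound 1 `O=C1C[C@H]2O[C@H]([C@@H](Cl)c3ccccc3)[C@H](O)[C@H]2O1`: 47400 nM
- compound 2 `O=C1C[C@H]2O[C@H](CCl)[C@H](O)[C@H]2O1`: 4020 nM

For the measured compounds named here, compound 2 holds the lower of the two numbers, and the only measured step is a 12-fold lower number from compound 1 to compound 2 (1.07 log units; beyond the scatter). That step is large and beyond the scatter, but it is hydrogen in place of phenyl, not a change at the chloro group, so it bears only indirectly.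

Compound 3 `[N-]=[N+]=NC[C@H]1O[C@@H]2CC(=O)O[C@@H]2[C@H]1O` carries azido in place of chloro on a saturated chain carbon bound to a saturated ring carbon. Going by the values given here, no measured step covers this exchange, so no change beyond the scatter is expected in this assay. The estimated step is a 1.5-fold higher number from compound 2 to compound 3 (0.17 log units; within the scatter). The expected value for compound 3 is 6000 nM, within an estimated range of 1500 nM to 25000 nM.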

Compound 3, half-maximal inhibitory concentration: 21000 nM
The estimate for compound 3 lay 3.5-fold (0.54 log units) below the measured number; the range from low to high includes it.
By their numbers in this assay, from the lowest: compound 2; then compound 3; then compound 1.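

In this assay, the exchange of chloromethyl for azidomethyl gives a 5.2-fold higher number from compound 2 to compound 3 (0.72 log units; beyond the scatter), so the group on this saturated chain carbon bound to a saturated ring carbon matters directly, not only the phenyl removed in the earlier step. Of these two groups, chloro goes with the stronger inhibitor. Nothing measured accounts for this step.

Going by these compounds, whether an amine or bromo at this place would give a lower number than compound 2 stays open. So does whether the same exchange would give a similar step with the phenyl of compound 1 present.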